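Hydroxy to dimethylamino on the aryl ring of compound 2

The compounds below may be only part of what the source reports. "The series", "measured", "known", "first", "only" and "open" are said of these compounds alone.

Measured so far:
Compound 1 `COc1ccc(/C=N\NC(=S)NC(C)(C)CCC[C@](C)(O)[C@@H]2CC=C(C)CC2)cc1` gives 6500 nM in a functional assay on MCF7 cells (Homo sapiens) for cytotoxicity, read by sulforhodamine B assay; a lower number here means a stronger inhibitor of growth, a higher number a weaker inhibitor of growth.
Compound 2 `CC1=CC[C@@H]([C@@](C)(O)CCCC(C)(C)NC(=S)N/N=C\c2ccc(O)cc2)CC1` gives 6230 nM in this assay.

Compound 2 holds the smaller of the two numbers, but the difference, a 1.0-fold lower number from compound 1 to compound 2 (0.02 log units; within the scatter), lies within the scatter, so the two compounds cannot be told apart in this assay.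

Compound 3 `CC1=CC[C@@H]([C@@](C)(O)CCCC(C)(C)NC(=S)N/N=C\c2ccc(N(C)C)cc2)CC1` is the next unmeasured compound. The change from compound 2 is dimethylamino in place of hydroxy on an aromatic carbon. Going by the values given here, the one measured step, hydrogen in place of methyl on the same oxygen, is within the scatter and does not cover the exchange of the whole hydroxy group for dimethylamino; no measured step bears directly on it. With nothing in the data pointing either way, the expected step in this assay is a 1.0-fold lower number from compound 2 to compound 3 (0.02 log units; within the scatter), which is none beyond the scatter. Compound 3 is therefore estimated at 6000 nM, with a range from 2500 nM to 15000 nM.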

Compound 3, concentration for 50% growth inhibition: 14000 nM
Compound 3: middle estimate off by 2.3-fold (0.37 log units), on the low side, within the range that was stated.
By their numbers in this assay, from the lowest: compounds 2 and 1 (each within the scatter of the next); then compound 3.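

In this assay, the aromatic carbon that carries these groups proves sensitive to the exchange: dimethylamino in place of hydroxy gives a 2.2-fold higher number from compound 2 to compound 3 (0.35 log units; beyond the scatter), and dimethylamino in place of methoxy gives a 2.2-fold higher number from compound 1 to compound 3 (0.33 log units; beyond the scatter). Going by these compounds alone, the earlier pair showed only that hydroxy and methoxy cannot be told apart here, whereas dimethylamino is the first group at this place to move the number beyond the scatter, modestly and toward weaker growth inhibition. Nothing available accounts for this shift.

Still open, from the compounds shown here alone, is whether the nitrogen or its two methyl groups carry the change, which an unsubstituted amine or a methylamino group at the same carbon would help separate. Also open, going by these compounds, is whether any group here, such as fluorine or a carboxylic acid, gives a lower number than hydroxy or methoxy.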